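The compounds below may be only part of what the source reports. "The series", "measured", "known", "first", "only" and "open" are said of these compounds alone.

Measured so far in an ADME assay on BHK-21 cells (Mesocricetus auratus) for cytotoxicity, with a stated time of 3 days; on this read-out higher numbers stand for lower toxicity in this test and lower numbers for higher toxicity in this test:
- compound 1 `O=C(CCSc1nnc(-c2ccncc2)s1)Nc1ccccc1`: the value is a limit of this assay, > 50000 nM
- compound 2 `O=C(CCSc1nnc(-c2ccncc2)s1)NCc1ccccc1Cl`: the value is likewise a limit of this assay, > 50000 nM

Compound 2 stands at the limit of > 50000 nM in this assay, at which 2 of the 2 values shown sit, so it cannot be placed relative to compound 1. The step that the two limits leave unreadable from compound 1 to compound 2 therefore gives no readable size. Compound 3 `O=C(CCSc1nnc(-c2ccncc2)s1)Nc1ccccc1Cl` differs from compound 2 by 2-chlorophenyl in place of 2-chlorobenzyl on an amide-type nitrogen. For the measured compounds named here, no measured step bears on this change with a readable size, so no shift beyond the scatter is expected in either direction in this assay. Compound 3 is expected at 80000 nM, between 30000 nM and 300000 nM, which means the estimated step that the limit leaves unreadable from compound 2 to compound 3, and most probably again only a limit will be reported.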

Compound 3, half-maximal cytotoxic concentration: > 50000 nM
Compound 3: a limit, no number; the forecaster's own chance of this, stated with the estimate: 85%; the middle value lies beyond the limit too.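

No step among compound 1, compound 2 and compound 3 can be read in this assay: the limit of > 50000 nM in this assay, at which 3 of the 3 values shown sit.

From the compounds shown here alone, whether phenyl, 2-chlorobenzyl or 2-chlorophenyl on the amide-type nitrogen changes the half-maximal cytotoxic concentration remains open.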